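The source may hold more compounds than are shown below. What is called first, only, known or untested is meant among the compounds shown, and "the series" means these compounds.

Measured compounds, with the value each gives in an assay on membranes from HEK293 cells for displacement of a labelled ligand from adenosine receptor A2b (Homo sapiens), read by scintillation counting, with a stated time of 30 min; on this read-out lower numbers stand for stronger inhibition and higher numbers for weaker inhibition:

Compound 1 `CC1=C(C(=O)OC2CCC2)C(c2ccco2)NC(=O)N1`: 95.1 nM
Compound 2 `CC1=C(C(=O)OC2CCCC2)C(c2ccco2)NC(=O)N1`: 577 nM
Compound 3 `CC1=C(C(=O)OC2CCC2)C(c2ccoc2)NC(=O)N1`: 307 nM

All three share a core and differ in two places. Compound 1 and compound 2 differ by cyclopentyl in place of cyclobutyl on an oxygen next to a carbonyl group; this change gives a 6.1-fold higher number from compound 1 to compound 2 (0.78 log units; beyond the scatter). Compound 1 and compound 3 differ in the core by furan-3-yl in place of furan-2-yl on a saturated ring carbon, a change that gives a 3.2-fold higher number from compound 1 to compound 3 (0.51 log units; beyond the scatter). Compound 4, `CC1=C(C(=O)OC2CCCC2)C(c2ccoc2)NC(=O)N1`, has not yet been measured. It differs from compound 3 by cyclopentyl in place of cyclobutyl on an oxygen next to a carbonyl group, the same change as that between compound 1 and compound 2, only made on the core of compound 3 instead of that of compound 1. Because the earlier step was a 6.1-fold higher number from compound 1 to compound 2 (0.78 log units; beyond the scatter), a step of similar size is expected here, roughly a 5.5-fold higher number from compound 3 to compound 4 (0.74 log units; beyond the scatter). Whether the change behaves alike on the two cores rests on a single measured pair, so the expectation is loose. Compound 4 is estimated to give about 1700 nM in this assay, most likely between 600 nM and 5000 nM.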

Compound 4, inhibition constant: 1010 nM
Beside the measured number, compound 4's estimate is 1.7-fold (0.23 log units) above it; the range from low to high includes it.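

Putting cyclopentyl in place of cyclobutyl on the oxygen again weakens binding in this assay, a 3.3-fold higher number from compound 3 to compound 4 (0.52 log units; beyond the scatter), and this step agrees with the one seen on the other core: the same change on two cores in this assay, a 6.1-fold higher number (0.78 log units; beyond the scatter) from compound 1 to compound 2 and a 3.3-fold higher number (0.52 log units; beyond the scatter) from compound 3 to compound 4, 1.8-fold (0.27 log units) apart, within the scatter of two such steps. The swap of furan-2-yl for furan-3-yl, made with cyclopentyl in place, gives a 1.8-fold higher number from compound 2 to compound 4 (0.24 log units; within the scatter), and although that step alone cannot be told from noise, it does not differ measurably from the same swap made with cyclobutyl in place: the same change on two cores in this assay, a 3.2-fold higher number (0.51 log units; beyond the scatter) from compound 1 to compound 3 and a 1.8-fold higher number (0.24 log units; within the scatter) from compound 2 to compound 4, 1.8-fold (0.27 log units) apart, within the scatter of two such steps. Within these four compounds, each change therefore carries from one core to the other without a detectable difference, but each comparison rests on a single pair of steps, so this shows neither a general rule for the series nor why the numbers move.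

The compounds shown leave open how a cyclopropyl or cyclohexyl group, or an open chain such as isopropyl, on that oxygen would behave, and whether a phenyl group in place of the furan would follow the same steps. Binding to other adenosine receptors also remains open, as only this assay is shown.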